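The compounds below may be only part of what the source reports. "The series", "measured", "known", "first", "only" and "open" are said of these compounds alone.

Values in a functional assay on PC-3 cells (Homo sapiens) for inhibition, read by MTT assay, with a stated time of 72 h; a higher number here means a weaker inhibitor, a lower number a stronger inhibitor:
- compound 1 `CCc1oc([C@H](C)/C=C(\C)[C@H](OC(C)=O)[C@H](C)[C@@H](OC(=O)CC(C)C)[C@@H](C)c2oc([C@@H](C)[C@H](CC)OC(C)=O)c(C)c(=O)c2C)c(C)c(=O)c1C` gives 7000 nM
- compound 2 `CCC(=O)O[C@@H](/C(C)=C/[C@@H](C)c1oc(CC)c(C)c(=O)c1C)[C@H](C)[C@@H](OC(=O)CC(C)C)[C@@H](C)c1oc([C@@H](C)[C@H](CC)OC(C)=O)c(C)c(=O)c1C` gives 2000 nM
- compound 3 `CCC(=O)[C@H](C)c1oc([C@H](C)[C@@H]2O[C@](O)([C@@H](C)c3oc(CC)c(C)c(=O)c3C)[C@@H](C)[C@@H](O)[C@@H]2C)c(C)c(=O)c1C` gives > 100000 nM, which is a limit and not a number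

Among the compounds with values here, compound 1 holds the higher of the two numeric values in this assay, and the only step measured from it is a 3.5-fold lower number from compound 1 to compound 2 (0.54 log units; beyond the scatter). Within the data shown here, compound 3 sits at the limit of > 100000 nM in this assay, at which 1 of the 3 values shown sits, and offers no single-place step from compound 1.

Compound 4 `CCc1oc([C@H](C)/C=C(\C)[C@H](OC(C)=O)[C@H](C)[C@@H](OC(=O)CC(C)C)[C@@H](C)c2oc([C@@H](C)[C@@H](O)CC)c(C)c(=O)c2C)c(C)c(=O)c1C` carries hydrogen in place of acetyl on an oxygen on a saturated carbon, so acetoxy becomes hydroxy: hydrogen in place of acetyl on an oxygen on a saturated carbon. Among the measured compounds shown here, no measured step removes an acetyl, so the evidence is indirect. Compound 2 adds a methyl on a saturated chain carbon bound to a carbonyl carbon and gains modestly, a 3.5-fold lower number from compound 1 to compound 2 (0.54 log units; beyond the scatter). Taking the whole acetyl away is a larger edit, and a modest move towards a higher number is expected. The expected change is a 1.7-fold higher number from compound 1 to compound 4 (0.23 log units; within the scatter). For compound 4 the estimated value is 12000 nM, with an expected range of 3500 nM to 45000 nM.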

Compound 4, half-maximal inhibitory concentration: 3000 nM
Compound 4: the middle estimate sits 4.0-fold (0.60 log units) above what was measured, outside the stated range (below it).
By their numbers in this assay, from the lowest: compounds 2 and 4 (each within the scatter of the next); then compound 1. At a limit, above all of these: compound 3.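

In this assay, the acetoxy group in the 2-acetoxy-1-methylbutyl chain can be exchanged for hydroxy without loss, giving a 2.3-fold lower number from compound 1 to compound 4 (0.37 log units; beyond the scatter). Within the data shown here, this is the first measured change at this position, and it shows that the acetyl on this oxygen is not required at this level of activity; the one earlier step, a 3.5-fold lower number from compound 1 to compound 2 (0.54 log units; beyond the scatter), lies at a different place in the molecule. No measurement shown gives a reason for the step at this position.

From the compounds shown here alone, whether the gain belongs to the free hydroxy or simply to the loss of the acetyl stays open. A methoxy group or an amine on this saturated carbon, or a longer ester such as butanoyloxy, would help separate the two readings.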